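A Smaller Group on the Ring Nitrogen of the Shared Core

This account rests on a few compounds, and the source may have more. Where it says the series, first, only, none or still open, it means among the compounds named here.

Compound 1, `CCN(CC)c1ccc2cc(C(=O)c3ccc(N4CCN(S(=O)(=O)c5ccc(Br)cc5)CC4)cc3)oc2c1`: > 40000 nM
Compound 2, `CCN(CC)c1ccc2cc(C(=O)c3ccc(N4CCN(S(=O)(=O)c5ccc([N+](=O)[O-])cc5)CC4)cc3)oc2c1`: > 40000 nM

In a functional assay on HeLa cells (Homo sapiens) for cytotoxicity, read by MTT assay, with a stated time of 48 h (on this read-out lower numbers stand for stronger inhibition and higher numbers for weaker inhibition), compound 1 gives > 40000 nM, which is a limit of the assay and not a number. Compound 2 gives > 40000 nM, likewise a limit. The step that the two limits leave unreadable from compound 1 to compound 2 therefore cannot be read, both values sitting at the limit of > 40000 nM in this assay, at which 2 of the 2 values shown sit. So compound 2 stands at the limit, with no numerical potency known.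

Compound 3, `CCOC(=O)N1CCN(c2ccc(C(=O)c3cc4ccc(N(CC)CC)cc4o3)cc2)CC1`, differs from compound 2 by ethoxycarbonyl in place of (4-nitrophenyl)sulfonyl on an amine nitrogen in a ring. Among the compounds with values here, the only measured step gives no readable size, so nothing in the data points to a gain or loss beyond the scatter for this change, and the expectation is that compound 3 also remains at the limit. Compound 3 is estimated at 40000 nM, with a range from 15000 nM to 120000 nM. This estimate means a step of a number no higher from compound 2 to compound 3 (the limit leaves the size open), expected to be none beyond the scatter.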

Compound 3, half-maximal inhibitory concentration: 20300 nM
Compound 3: middle estimate off by 2.0-fold (0.29 log units), on the high side, and the stated range covers the measured number.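

In this assay, within the data shown here, compound 3 is the first compound here to give a real number, so on this amine nitrogen in a ring, ethoxycarbonyl, which has no ring and fewer heavy atoms than either sulfonyl group it replaces, brings the read-out within measuring range. The steps read an at least 1.9-fold lower number from compound 2 to compound 3 (0.29 log units; that floor lies within the scatter) and an at least 1.9-fold lower number from compound 1 to compound 3 (0.29 log units; that floor lies within the scatter), and each is only a floor. Compound 1 and compound 2 each stay at a limit and not a number: the limit of > 40000 nM in this assay, at which 2 of the 3 values shown sit.

As far as these compounds go, how far compound 3 truly stands from compound 1 and compound 2 therefore remains unknown. Also open, from the compounds shown here alone, is whether the measurable value depends on the ethoxycarbonyl itself or only on the absence of the arylsulfonyl group, which an acetyl group, a methyl group or a free ring amine on the same nitrogen could help to separate.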